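A Sulfoxide Acid Replaces the Thioether on a Nucleoside

This account rests on a few compounds, and the source may have more. Where it says the series, first, only, none or still open, it means among the compounds named here.

Of the compounds shown here, three have been measured in an assay on BHK21 (C13) cells (Mesocricetus auratus) for inhibition of thymidine kinase, cytosolic (Cricetulus griseus), using Lineweaver-Burk analysis; a lower number here means a stronger inhibitor, a higher number a weaker inhibitor. Compound 1 `O=C(CI)NCCCC(=O)Nc1cn([C@H]2C[C@H](O)[C@@H](CO)O2)c(=O)[nH]c1=O` gives 3100000 nM, and compound 2 `O=C(CI)NCCCCCC(=O)Nc1cn([C@H]2C[C@H](O)[C@@H](CO)O2)c(=O)[nH]c1=O` gives 3000000 nM; the step of a 1.0-fold lower number from compound 1 to compound 2 (0.01 log units; within the scatter). Compound 3 `CCSC[C@H]1O[C@@H](n2cc(C)c(=O)[nH]c2=O)C[C@@H]1O` gives 21500000 nM, the highest of the three numbers, standing beyond the scatter from both of the others. Compound 4 `Cc1cn([C@H]2C[C@H](O)[C@@H](C[S+]([O-])CCC(=O)O)O2)c(=O)[nH]c1=O` differs from compound 3 by a group of 7 heavy atoms (3 carbon, 3 oxygen, 1 sulfur; no ring) in place of a group of 3 heavy atoms (2 carbon, 1 sulfur; no ring), on a saturated chain carbon bound to a saturated ring carbon. For the measured compounds named here, no measured step touches this position, and the only step on record, a chain lengthening between two other compounds, stayed within the scatter, so nothing here points in a direction. Expected, therefore, is a 1.1-fold lower number from compound 3 to compound 4 (0.03 log units; within the scatter), with wide uncertainty. Compound 4 is estimated at 20000000 nM, between 4000000 nM and 100000000 nM.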

Compound 4, half-maximal inhibitory concentration: 130000 nM
For compound 4 the middle estimate is 150-fold (2.19 log units) above the measured one; measured number below the stated range.
By their numbers in this assay, from the lowest: compound 4; then compounds 2 and 1 (each within the scatter of the next); then compound 3.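

In this assay, the group on this saturated chain carbon bound to a saturated ring carbon clearly matters: the group of 7 heavy atoms in place of ethylsulfanyl gives a 170-fold lower number from compound 3 to compound 4 (2.22 log units; beyond the scatter). For the compounds shown here, this is the first step on record beyond the scatter between two compounds that differ in one place, and it shows that the number can fall sharply through a change here. No measurement shown explains this drop.

From the compounds shown here alone, the entering group brings a sulfoxide, a carboxylic acid and a longer chain together, so which of these carries the step stays open. A sulfoxide with a plain ethyl group, or a thioether ending in a carboxylic acid, would help separate them.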